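This account rests on a few compounds, and the source may have more. Where it says the series, first, only, none or still open, it means among the compounds named here.

The measured compounds:
compound 1, `Cc1ccc(C(=O)CCc2nnc(-c3ccccc3)o2)c(C)c1`, gives 58% in a functional assay on the whole organism (strain Wistar) for inhibition, with Rattus norvegicus as the target, with stated times of 30 min and 3 h, at a dose of 20 mg/kg by the oral route; on this read-out higher numbers stand for more inhibition at the one dose given (going by the name of the read-out) and lower numbers for less inhibition;
compound 2, `Cc1ccc(C(=O)CCc2nnc(-c3ccccc3Cl)o2)c(C)c1`, gives 60.5% in this assay;
compound 3, `Cc1ccc(C(=O)CCc2nnc(COc3ccccc3)o2)cc1`, gives 42% in this assay.

Compound 3 stands lowest of the three, below both compound 1 and compound 2 by amounts beyond the scatter. Compound 4, `Cc1ccc(C(=O)CCc2nnc(COc3ccccc3)o2)c(C)c1`, differs from compound 3 by methyl in place of hydrogen on an aromatic carbon. Within the data shown here, no measured step shows this change. Among the measured compounds shown here, the only measured step, a number 2.5 percentage points higher from compound 1 to compound 2 (within the scatter), concerns a different group and stayed within the scatter; compound 1 and compound 3 differ in more than one place, so their values alone do not isolate the methyl. A step within the scatter is therefore expected for compound 4 in this assay, a number 5 percentage points higher from compound 3 to compound 4 (within the scatter). Compound 4 is estimated at 47%, between 30% and 63%.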

Compound 4, a percentage reported as inhibition, in the whole organism at one dose (the size of the read-out at that dose, not a potency): 45.7%
Estimate against measurement, compound 4: 1.3 percentage points above; the range from low to high includes it.
By their numbers in this assay, from the lowest: compounds 3 and 4 (each within the scatter of the next); then compounds 1 and 2 (each within the scatter of the next).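

In this assay, methyl in place of hydrogen, turning 4-methylphenyl into 2,4-dimethylphenyl, gives a change that stays within the scatter (a number 3.7 percentage points higher from compound 3 to compound 4 (within the scatter)). The exchange of the other group weighs more, with phenoxymethyl in place of phenyl (a number 12.3 percentage points lower from compound 1 to compound 4 (beyond the scatter)) and in place of 2-chlorophenyl (a number 14.8 percentage points lower from compound 2 to compound 4 (beyond the scatter)), both modest steps beyond the scatter. Nothing given here accounts for these differences.

As far as these compounds go, whether an amine or a longer chain at this position would likewise stay within the scatter remains open. So does whether methyl has the same small effect alongside phenyl rather than phenoxymethyl.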